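The source may hold more compounds than are shown below. What is called first, only, known or untested is meant among the compounds shown, and "the series" means these compounds.

Measured so far:
Compound 1 `CCc1sc(N(CC2CC2)[C@H](C)c2ccc(-c3cc(C)ccc3-c3nc(=O)o[nH]3)cc2)nc1C(=O)NS(=O)(=O)C1CC1`: 2.9 h
Compound 2 `Cc1ccc(-c2nc(=O)o[nH]2)c(-c2ccc([C@@H](C)N(CC3CC3)c3nc(C(=O)NS(=O)(=O)C4CC4)c(C4CCC4)s3)cc2)c1`: 5.7 h

Both numbers come from an ADME assay on the whole organism (Macaca fascicularis); on this read-out lower numbers stand for a shorter-lived compound and higher numbers for a longer-lived compound. Of the two, the number of compound 2 is the larger, yet the step of a 2.0-fold higher number from compound 1 to compound 2 (0.29 log units; within the scatter) is within the scatter, so the two compounds cannot really be told apart on this read-out. Compound 3 `Cc1ccc(-c2nc(=O)o[nH]2)c(-c2ccc([C@@H](C)N(CC3CC3)c3nc(C(=O)NS(=O)(=O)C4CC4)c(C4CC4)s3)cc2)c1` differs from compound 2 in one place: cyclopropyl in place of cyclobutyl on an aromatic carbon. For the measured compounds named here, the only measured step that bears on this place, a 2.0-fold higher number from compound 1 to compound 2 (0.29 log units; within the scatter), exchanged one small carbon group for another there and stayed within the scatter. A change from a four-membered to a three-membered ring at the same place therefore gives no reason to expect a step beyond the scatter. A small shift downward is estimated because compound 1, with the smaller ethyl group at this place, gave 2.9 h. The expected step is a 1.4-fold lower number from compound 2 to compound 3 (0.13 log units; within the scatter). Compound 3 is expected to give about 4.2 h, within a range from 2.2 h to 8 h.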

Compound 3, mean residence time: 6 h
For compound 3 the middle estimate is 1.4-fold (0.15 log units) below the measured one; the range from low to high includes it.
By their numbers in this assay, from the lowest: compounds 1, 2 and 3 (each within the scatter of the next, the first and the last beyond it).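

In this assay the step with cyclopropyl in place of cyclobutyl on this aromatic carbon, next to the ring sulfur, is a 1.1-fold higher number from compound 2 to compound 3 (0.02 log units; within the scatter) and shows that the two rings cannot be told apart here. For the compounds shown here, with cyclopropyl in place of ethyl at the same place the step is a 2.1-fold higher number from compound 1 to compound 3 (0.32 log units; beyond the scatter) and is the first at this position to pass the scatter, though only modestly, while cyclobutyl in place of ethyl, a 2.0-fold higher number from compound 1 to compound 2 (0.29 log units; within the scatter) and so inside the scatter, goes against any rule that a ring here beats ethyl. Nothing shown gives a reason for these steps.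

All three groups at this place are small and made of carbon only. On these data alone, how an amine, a methoxy group or a longer chain such as n-butyl would fare here remains open.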